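Chloro in place of bromo on compound 2

The source may hold more compounds than are shown below. What is called first, only, known or untested is meant among the compounds shown, and "the series" means these compounds.

Compound 1 `CCCCNc1[nH]c2c(F)cc(F)cc2c(=O)c1C(C)=O` and compound 2 `CC(=O)c1c(Nc2ccc(Br)cc2)[nH]c2c(F)cc(F)cc2c1=O` share a core and differ in the group on one nitrogen. In an ADME assay on Vero cells (Chlorocebus sabaeus) for cytotoxicity (a lower number here means that less compound is tolerated, a higher number that more compound is tolerated), compound 1 gives > 25000 nM, which is a limit of the assay and not a number. In this assay compound 2 gives > 25000 nM, which is likewise only a limit. All the evidence in hand is the limit of > 25000 nM in this assay, at which 2 of the 2 values shown sit. Going by the values given here, the one measured step is a step that the two limits leave unreadable from compound 1 to compound 2, with 4-bromophenyl in place of butyl on a nitrogen on an aromatic ring, so it offers no size to carry forward.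

Compound 3 `CC(=O)c1c(Nc2ccc(Cl)cc2)[nH]c2c(F)cc(F)cc2c1=O` departs from compound 2 by chloro in place of bromo on an aromatic carbon, para to a large group. Among the compounds with values here, no step of this kind has been measured. Within the data shown here, the only guide is the wider exchange in a step that the two limits leave unreadable from compound 1 to compound 2, which did not bring a number into view. No change in either direction beyond the scatter is therefore expected, and the expected step is a step that the limit leaves unreadable from compound 2 to compound 3. For compound 3 the estimated value is 30000 nM, with an expected range from 15000 nM to 60000 nM.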

Compound 3, half-maximal cytotoxic concentration: > 25000 nM
Compound 3 ended at the assay's limit (the forecaster's own chance of this, stated with the estimate: 85%); the middle value lies beyond the limit too.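

Going by these compounds alone, no step among compound 1, compound 2 and compound 3 can be read in this assay, since each of the three ends at a limit and not at a number: the limit of > 25000 nM in this assay, at which 3 of the 3 values shown sit.

The compounds shown leave open how far each lies beyond that limit, and whether any change to the group on the nitrogen would bring a number into view.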